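Series notes: from compound 3 to compound 4

This account rests on a few compounds, and the source may have more. Where it says the series, first, only, none or still open, it means among the compounds named here.

Compound 3 `COc1ccc(-c2nnc(SC/C(=N/O)c3ccccc3)n2-c2ccccc2)cc1OC` holds the highest of the three numbers in a functional assay on the whole organism (strain albino) for inhibition, with Rattus norvegicus as the target, read by paw edema, with a stated time of 4 h, at a dose of 0.28 mmol/kg by the oral route (a lower number here means less inhibition, a higher number more inhibition at the dose given (going by the name of the read-out)), where compound 3 gives 81%. Compound 1 `COc1ccc(-c2nnc(SC/C(=N/O)c3ccccc3)n2-c2ccccc2)cc1` lies nearest, giving 80%, and the two are within the scatter of each other, so no order between them is claimed. Compound 2 `COc1ccc(-c2nnc(SCC(=O)c3ccccc3)n2-c2ccccc2)cc1OC` lies furthest, giving 65%. The step of a number 1 percentage points higher from compound 1 to compound 3 (within the scatter) came with methoxy in place of hydrogen on an aromatic carbon, while the step of a number 16 percentage points higher from compound 2 to compound 3 (beyond the scatter) came with the change on a saturated chain carbon bound to a sulfur.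

Compound 4 `COc1cc(-c2nnc(SC/C(=N/O)c3ccccc3)n2-c2ccccc2)cc(OC)c1OC` has not yet been measured. It differs from compound 3 by methoxy in place of hydrogen on an aromatic carbon. Among the measured compounds shown here, the measured step that bears on this is the one from compound 1 to compound 3, which was itself methoxy in place of hydrogen on an aromatic carbon, and it stayed within the scatter. The step on the chain carbon does not touch the change made here. On that basis no move beyond the scatter is expected in this assay for compound 4, that is, an expected step of a number 1 percentage points lower from compound 3 to compound 4 (within the scatter). Compound 4 is therefore estimated at 80% in this assay, with a range from 68% to 90%.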

Compound 4, a percentage reported as inhibition, in the whole organism at one dose (the size of the read-out at that dose, not a potency): 76%
For compound 4 the middle estimate is 4 percentage points above the measured one, and the stated range covers the measured number.
By their numbers in this assay, from the lowest: compound 2; then compounds 4, 1 and 3 (each within the scatter of the next).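

In this assay the step of a number 5 percentage points lower from compound 3 to compound 4 (within the scatter) came with methoxy in place of hydrogen on an aromatic carbon, this time ortho to a methoxy group and meta to a large group. Together with the step of a number 1 percentage points higher from compound 1 to compound 3 (within the scatter) on the same ring, this gives two readings of the exchange at different places on that ring, and neither lies beyond the scatter at this single dose, though a difference that shows only at other doses cannot be excluded. No measurement is at hand that explains why the number stays in place with this exchange.

Among the compounds shown here, it remains open whether an amine, a carboxylic acid or a longer alkoxy chain at this place on the ring would also stay within the scatter, since methoxy is the only group read here. Also open, going by these compounds, is whether the change on the saturated chain carbon bound to a sulfur, read only as the step of a number 16 percentage points higher from compound 2 to compound 3 (beyond the scatter) in the series, would give a step of similar size with the added methoxy of compound 4 present.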